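The source may report more compounds than this note shows. Statements on the series, on what has been measured and on what is new or still open speak of the compounds shown alone.

Compound 1 `Cc1cc(-c2cnc(NCc3c(F)ccc4c3CCO4)c3cn[nH]c(=O)c23)n(C)n1`: 24 mL.min-1.g-1
Compound 2 `CN(C)Cc1ccc2c(c1)CN(c1cnc(NCc3c(F)ccc4c3CCO4)c3cn[nH]c(=O)c13)C2=O`: 32 mL.min-1.g-1

In an ADME assay on microsomes from liver (Homo sapiens) for metabolic stability, read by LC-MS, using NADPH, with stated times of 5 min and 30 min, tested at 1 uM (a lower number here means slower removal, a higher number faster removal of the compound), compound 1 gives 24 mL.min-1.g-1, the lower of the two numbers shown, while compound 2 gives 32 mL.min-1.g-1, a gap that lies within the usual scatter. Compound 3 `Cc1ncccc1-c1cnc(NCc2c(F)ccc3c2CCO3)c2cn[nH]c(=O)c12` has not yet been measured and differs from compound 1 by one change, (2-methylpyridin-3-yl in place of 1,3-dimethyl-1H-pyrazol-5-yl on an aromatic carbon). For the measured compounds named here, no measured pair carries this change, so nothing in the data shows its effect in this assay. A step of modest size, or none beyond the scatter, is expected: a 1.3-fold higher number from compound 1 to compound 3 (0.10 log units; within the scatter). Compound 3 is therefore expected to give 30 mL.min-1.g-1, within a range of 15 mL.min-1.g-1 to 60 mL.min-1.g-1.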

Compound 3, intrinsic clearance in microsomes: 41 mL.min-1.g-1
For compound 3 the middle estimate is 1.4-fold (0.14 log units) below the measured one, and the stated range covers the measured number.
By their numbers in this assay, from the lowest: compounds 1, 2 and 3 (each within the scatter of the next).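

In this assay, 2-methylpyridin-3-yl in place of 1,3-dimethyl-1H-pyrazol-5-yl gives a 1.7-fold higher number from compound 1 to compound 3 (0.23 log units; within the scatter). For the compounds shown here, this is the first reading at this position of a change from a five-membered aromatic ring with 2 hetero atoms to a six-membered aromatic ring with 1 hetero atom, and the step stays within the scatter. Nothing measured here explains the step.

Still open, as far as these compounds go, is how a nitrile or a carboxylic acid on this ring would read in this assay. From the compounds shown here alone, whether the methyl of 2-methylpyridin-3-yl contributes to the number also remains unknown.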